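Swapping the aryl group at the ring nitrogen's neighbour

The source may report more compounds than this note shows. Statements on the series, on what has been measured and on what is new or still open speak of the compounds shown alone.

Of the compounds shown here, two of a shared core have been measured in a physicochemical assay for solubility, read by spectrophotometry, in phosphate buffer, with a stated time of 18 h, at pH 7.4; a lower number here means a less soluble compound, a higher number a more soluble compound. Compound 1 `CCc1ccc(-c2nc3c(c(C)nn3-c3ccccc3)c(-c3ccccc3I)c2C#N)cc1` gives 8500 nM in this assay. Compound 2 `Cc1nn(-c2ccccc2)c2nc(-c3ccc(F)cc3)c(C#N)c(-c3ccccc3O)c12` gives 6000 nM in this assay; its number and that of compound 1 lie within the usual scatter of each other, so the two cannot be ranked on these data.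

Compound 3 `CCc1cccc(-c2nc3c(c(C)nn3-c3ccccc3)c(-c3ccccc3O)c2C#N)c1` has not yet been measured. It differs from compound 2 in one place: 3-ethylphenyl in place of 4-fluorophenyl on an aromatic carbon. The 2-hydroxyphenyl group and the rest of the core are kept.

Going by the values given here, with no measured pair showing what this exchange does, the size of the step rests on compound 1 and compound 2 alone, whose values in this assay sit close together. The account expects a modest fall in solubility for compound 3, one that may not clear the scatter, as the step of a 1.5-fold lower number from compound 2 to compound 3 (0.18 log units; within the scatter) expresses. On that basis the value estimated for compound 3 in this assay is 4000 nM, with a range from 1500 nM to 11000 nM.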

Compound 3, solubility: 11000 nM
For compound 3 the middle estimate is 2.8-fold (0.44 log units) below the measured one; low and high end bracket the measured number.
By their numbers in this assay, from the lowest: compounds 2, 1 and 3 (each within the scatter of the next).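

The exchange of 4-fluorophenyl for 3-ethylphenyl, on the aromatic carbon next to the ring nitrogen, can now be read directly: in this assay it amounts to a 1.8-fold higher number from compound 2 to compound 3 (0.26 log units; within the scatter) with the 2-hydroxyphenyl group and the rest of the core kept. The position thus carries either aryl group, one with a fluorine and one with an ethyl chain, without a difference in this read-out that can be told apart from the scatter of repeated measurements. No measurement bears on what lies behind the two numbers.

This single exchange replaces the fluorine with an ethyl chain and also changes where the substituent sits on the aromatic ring, so the compounds shown do not separate these two changes, and 3-fluorophenyl and 4-ethylphenyl partners carrying the 2-hydroxyphenyl group would be needed to do so. Also open, from the compounds shown here alone, is whether an amine or a carboxylic acid on this aromatic ring would give a step that clears the scatter, and whether the same exchange gives a comparable step with a group other than 2-hydroxyphenyl on the core.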